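The compounds below may be only part of what the source reports. "The series", "measured", "known", "first", "only" and "open" are said of these compounds alone.

Three chalcone-like compounds share one core, each carrying the same pair of allyloxy chains, and were tested in a toxicity assay on cells (Macrophage, Mus musculus, strain BALB/c) for cytotoxicity, read by MTT assay; on this read-out higher numbers stand for weaker inhibition and lower numbers for stronger inhibition. Compound 1 `C=CCOc1cc(OC)c(C(=O)/C=C/c2ccc([N+](=O)[O-])cc2)c(OCC=C)c1` gives 13200 nM in this assay. Compound 3 `C=CCOc1cc(/C=C/C(=O)c2c(O)cc(O)cc2OC)cc(OCC=C)c1Br` gives 11500 nM in this assay, and these two numbers lie within the usual scatter of each other, so they show about the same weak inhibition rather than a difference between them. Compound 2 `C=CCOc1cc(OC)c(C(=O)/C=C/c2ccncc2)c(OCC=C)c1` gives "not determined" (no result reported) in this assay, so no number for it exists; it stands only as a structure beside the other two.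

The piece now follows the step from compound 2 to compound 4 `C=CCOc1cc(OC)c(C(=O)/C=C/c2ccc(Cl)cc2)c(OCC=C)c1`, which has not yet been measured. The change between the two structures is 4-chlorophenyl in place of pyridin-4-yl on a double-bonded chain carbon bound to a double-bonded chain carbon. Everything else in the molecule stays as it is.

Among the compounds with values here, with no measured value for compound 2 and no pair of measured compounds that differ in one place, nothing in the data shows how this particular exchange shifts the read-out. Within the data shown here, the only guide is that both measured members, compound 1 and compound 3, sit at a similar level. Compound 4 is therefore expected to land near that same level, with an estimated value of 12000 nM and a plausible range from 4000 nM to 40000 nM in this assay.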

Compound 4, half-maximal inhibitory concentration: 13000 nM
Compound 4: the middle estimate sits 1.1-fold (0.03 log units) below what was measured; the range from low to high includes it.
By their numbers in this assay, from the lowest: compounds 3, 4 and 1 (each within the scatter of the next).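

In this assay, within the data shown here, the first step that can be read at this position is a 1.0-fold lower number from compound 1 to compound 4 (0.01 log units; within the scatter) and it lies within the usual scatter, so chloro in place of nitro on an aromatic carbon leaves the read-out where it was, as far as this measurement can tell. The exchange of pyridin-4-yl for 4-chlorophenyl cannot be read, as compound 2 has no number, so the new information concerns only the two groups on the aromatic ring of compound 1 and compound 4, which give values that cannot be told apart. No measurement shown here offers an explanation for this flat result.

From the compounds shown here alone, two groups that give matching values are a narrow sample, so it remains open whether an amine or a carboxylic acid on that same aromatic carbon would shift the read-out beyond the scatter. Going by these compounds, it also remains open whether swapping the two allyloxy chains for a longer chain, such as hexyloxy, would change the level that compound 1 and compound 4 share.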